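The source may hold more compounds than are shown below. What is called first, only, known or untested is meant among the compounds shown, and "the series" means these compounds.

Measured so far:
Compound 1 `CC1(C)OC(/C=C/c2cccnc2)=CC1=O`: 9 mg/kg
Compound 2 `CC1(C)OC(/C=C/c2ccnc3ccccc23)=CC1=O`: 2.5 mg/kg
Compound 3 `CC1(C)OC(/C=C/c2ccc(Br)cc2)=CC1=O`: 18 mg/kg

These three compounds share one core and differ in the group carried on it. All were tested in a functional assay on the whole organism for inhibition, with Rattus norvegicus as the target, with a stated time of 1 h; on this read-out lower numbers stand for an effect already at smaller amounts and higher numbers for an effect only at larger amounts of compound. There, compound 3 gives 18 mg/kg, which lies within the usual scatter of compound 1 at 9 mg/kg. Compound 2 at 2.5 mg/kg has a lower number than compound 3, and that gap lies beyond the scatter. Compound 3 therefore stands level with compound 1 and clearly apart from compound 2.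

The next compound is compound 4 `CC1(C)OC(/C=C/c2ccc(F)cc2)=CC1=O`, and its difference from compound 3 is small: fluoro in place of bromo on an aromatic carbon. Fluoro takes the place of bromo on an aromatic carbon, para to a large group, and the rest of the structure stays the same. For the measured compounds named here, no two measured compounds differ in only one place, so the data contain no direct measure of such a swap. Going by the values given here, compound 3 at 18 mg/kg is the only anchor, as the sole measured compound with a halogen. A small move toward a lower number is expected, most likely not beyond the scatter, and the estimated change is a 1.5-fold lower number from compound 3 to compound 4 (0.18 log units; within the scatter). For compound 4 the expected value is 12 mg/kg, with an estimated range from 4.5 mg/kg to 32 mg/kg.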

Compound 4, dose for half-maximal effect: 11 mg/kg
The estimate for compound 4 lay 1.1-fold (0.04 log units) above the measured number; measured number inside the range.
By their numbers in this assay, from the lowest: compound 2; then compounds 1, 4 and 3 (each within the scatter of the next).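

In this assay, for the compounds shown here, fluoro in place of bromo on an aromatic carbon, para to a large group, gives a 1.6-fold lower number from compound 3 to compound 4 (0.21 log units; within the scatter) and so provides the first comparison of two compounds that differ in only one place. At this position, with the rest of the structure unchanged, exchanging one of these halogens for the other leaves the number within the usual scatter, so this read-out does not separate the two compounds. No measured property bears on this result, and the step therefore stays a bare observation without an explanation.

The compounds shown leave open whether a group of another kind on this aromatic carbon, such as an amine, a methoxy group or a carboxylic acid, would move the number beyond the scatter, as only bromo and fluoro can be compared here. They also leave open how much of the lower number of compound 2 (2.5 mg/kg) comes from its aromatic group, as no single change connects compound 2 with compound 3 or compound 4.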